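Chloro for isopropyl on the aryl of compound 1

A few compounds are considered here, and "the series" means these few. Any claim that something is new, unique, unknown or untested is made for them only; others in the source may bear on it.

Compound 1 `CC(C)c1ccc(-c2nc(CN3CCCC3)nn2C)cc1` was tested in an assay on membranes from Jurkat cells for displacement of a labelled ligand from Sigma intracellular receptor 2 (Homo sapiens), read by scintillation counting, with a stated time of 1 h (on this read-out higher numbers stand for weaker inhibition and lower numbers for stronger inhibition), where compound 1 gives 1000 nM. Compound 3 `Cn1nc(CN2CCCC2)nc1-c1cccc(-c2ccccc2)c1` is its nearest neighbour among the measured compounds, and in this assay compound 3 gives 1000 nM, level with compound 1 at the digits shown and within the scatter. Compound 2 `Cn1nc(CN2CCCC2)nc1-c1ccc2ccsc2c1` returned only a limit of the assay, as in this assay compound 2 gives > 1000 nM. One of the three values shown thus sits at the limit (the limit of > 1000 nM in this assay, at which 1 of the 3 values shown sits).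

Compound 4 `Cn1nc(CN2CCCC2)nc1-c1ccc(Cl)cc1` has not yet been measured in this assay. It differs from compound 1 in one place: chloro in place of isopropyl on an aromatic carbon of a six-membered aromatic ring of carbon only, para to a large group. For the measured compounds named here, no step between measured compounds speaks to this change, so the expectation for compound 4 is a step of no more than the scatter, slightly toward weaker inhibition if at all, a 1.3-fold higher number from compound 1 to compound 4 (0.11 log units; within the scatter). Compound 4 is accordingly estimated at 1300 nM, with a range from 400 nM to 4000 nM.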

Compound 4, inhibition constant: > 1000 nM
Compound 4: only a limit was reported; the forecaster's own chance of this, stated with the estimate: 45%; the middle value is on the limit's open side.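

In this assay compound 4 gives > 1000 nM, which is a limit of the assay and not a number. For the compounds shown here, this is the first look at a change at this aromatic carbon: putting chloro in place of isopropyl brings no gain in inhibition, with a number no lower from compound 1 to compound 4 (the limit leaves the size open), and the size of this step cannot be read. Compound 4 thus joins the compounds at the edge of what the assay reports: the limit of > 1000 nM in this assay, at which 2 of the 4 values shown sit.

The compounds shown leave open whether a methoxy group or an amine on this aromatic carbon would give stronger inhibition than compound 1, which gives 1000 nM. They also leave open whether a longer alkyl chain in place of isopropyl would move the reading at all, in either direction.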